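Swapping the pendant ring from nitrile to dimethyl

This account rests on a few compounds, and the source may have more. Where it says the series, first, only, none or still open, it means among the compounds named here.

Measured compounds:
- Compound 1, `O=C(Nc1cccnc1)c1ccccc1OCc1ccccc1C(F)(F)F`: 2100 nM
- Compound 2, `N#Cc1cccc(COc2ccccc2C(=O)Nc2cccnc2)c1`: 60700 nM

Both compounds share one core and differ only in the ring hanging from the saturated chain carbon bound to an oxygen on an aromatic ring. In an assay on lysate for inhibition of phosphatidylcholine:ceramide cholinephosphotransferase 2 (Homo sapiens), read by HPLC, with stated times of 30 min and 2 h (a lower number here means a stronger inhibitor, a higher number a weaker inhibitor), compound 1 gives 2100 nM, while compound 2 gives 60700 nM, the highest of the two numbers; that gap lies well beyond the usual scatter, so compound 2 is clearly the weaker of the pair.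

Compound 3, `Cc1cccc(C)c1COc1ccccc1C(=O)Nc1cccnc1`, has not yet been measured. It carries 2,6-dimethylphenyl in place of 3-cyanophenyl on a saturated chain carbon bound to an oxygen on an aromatic ring. Since compound 1 already shows that another substituted phenyl ring at this place can give a far lower number than compound 2, the step of a 12-fold lower number from compound 2 to compound 3 (1.08 log units; beyond the scatter) is expected to be a marked drop, beyond the scatter. For compound 3 the value in this assay is therefore estimated at 5000 nM, within a range from 1500 nM to 20000 nM.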

Compound 3, half-maximal inhibitory concentration: 890 nM
Estimate against measurement, compound 3: 5.6-fold (0.75 log units) above; measured number outside the range, below it.
By their numbers in this assay, from the lowest: compound 3; then compound 1; then compound 2.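

In this assay, replacing 3-cyanophenyl with 2,6-dimethylphenyl gives a 68-fold lower number from compound 2 to compound 3 (1.83 log units; beyond the scatter), although the two rings have the same count of heavy atoms. This place on the saturated chain carbon therefore responds strongly to what the ring carries, and the entering ring, made of carbon only and with no hydrogen-bond acceptor, still gives the lowest number of the three compounds. No measurement shown here explains why this exchange has so large an effect.

The change removes a nitrile and adds two methyl groups at once, so the contribution of each remains unresolved. A plain phenyl ring, or one carrying a single methyl or a methoxy group, would help separate these contributions, and the compounds shown do not reveal how such rings would behave.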